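The source may report more compounds than this note shows. Statements on the series, on what has been measured and on what is new or still open speak of the compounds shown alone.

Compound 1 `CC1=NC(C)=C(C(=O)O)C(c2ccccc2)/C1=C(\O)OC/C=C/c1ccccc1`: 2000 nM
Compound 2 `CC1=NC(C)=C(C(=O)O)C(c2cccc(C(=O)O)c2)/C1=C(\O)OC/C=C/c1ccccc1`: 37000 nM
Compound 3 `CC1=NC(C)=C(C(=O)O)C(c2cccc(Cl)c2)/C1=C(\O)OC/C=C/c1ccccc1`: 1000 nM

These three compounds share one core and differ only in the group carried on the phenyl ring attached to it. All three were tested in a functional assay on IMR-32 cells for inhibition of Voltage-dependent N-type calcium channel subunit alpha-1B (Homo sapiens), read by calcium flux; on this read-out lower numbers stand for stronger inhibition and higher numbers for weaker inhibition. Compound 3, which carries a chloro on that ring, shows the lowest number of the three. Its gap to compound 1 is small: a 2.0-fold lower number from compound 1 to compound 3 (0.30 log units; within the scatter). Its gap to compound 2, which carries a carboxy in that position, is large: a 37-fold lower number from compound 2 to compound 3 (1.57 log units; beyond the scatter). The matching comparison of hydrogen against carboxy reads a 19-fold higher number from compound 1 to compound 2 (1.27 log units; beyond the scatter).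

Compound 4 `CC1=NC(C)=C(C(=O)O)C(c2cccc(I)c2)/C1=C(\O)OC/C=C/c1ccccc1` differs from compound 3 in one respect: iodo in place of chloro on an aromatic carbon. Going by the values given here, no measured step here swaps one halogen for another, so the closest guide is the chloro-for-hydrogen step, a 2.0-fold lower number from compound 1 to compound 3 (0.30 log units; within the scatter), which stayed within the scatter, while the only large effect seen, a 37-fold lower number from compound 2 to compound 3 (1.57 log units; beyond the scatter), involved a carboxy group that compound 4 does not carry. The step from compound 3 to compound 4 is therefore expected to be small, a 1.3-fold lower number from compound 3 to compound 4 (0.10 log units; within the scatter), and not beyond the scatter. For compound 4 in this assay the estimated value is 800 nM, with a range from 300 nM to 2500 nM.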

Compound 4, half-maximal inhibitory concentration: 1700 nM
For compound 4 the middle estimate is 2.1-fold (0.33 log units) below the measured one; low and high end bracket the measured number.
By their numbers in this assay, from the lowest: compounds 3, 4 and 1 (each within the scatter of the next); then compound 2.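

In this assay, iodo in place of chloro at this position gives a 1.7-fold higher number from compound 3 to compound 4 (0.23 log units; within the scatter) and iodo in place of hydrogen gives a 1.2-fold lower number from compound 1 to compound 4 (0.07 log units; within the scatter); both steps stay within the scatter, so hydrogen, chloro and iodo cannot be told apart here, even though iodine is a heavier atom than chlorine. The large gap to the carboxy compound also proves not to be tied to chloro alone, since iodo in place of carboxy gives a 22-fold lower number from compound 2 to compound 4 (1.34 log units; beyond the scatter), a step beyond the scatter, like the one seen earlier with chloro. Across these four compounds, then, carboxy is the only group that stands apart, but no measurement shown here explains why any of these groups reads as it does.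

As far as these compounds go, it remains open whether an amine, a methoxy group or an amide at this position would read like the halogens or like carboxy. The compounds shown also leave open whether a methyl ester of the carboxylic acid would keep the large step, and whether any of these groups would read the same on a different carbon of the ring.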